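The source may hold more compounds than are shown below. What is called first, only, known or untested is meant among the compounds shown, and "the series" means these compounds.

Compound 1, `COc1ccc(NC(=S)N/N=C\c2ccnc3ccccc23)cc1` — in a functional assay on MCF7 cells (Homo sapiens) for cytotoxicity, read by MTT assay, with a stated time of 48 h (a lower number here means a stronger inhibitor, a higher number a weaker inhibitor), compound 1 gives 990 nM
Compound 2, `S=C(N/N=C\c1ccnc2ccccc12)Nc1cccnc1` — compound 2 gives 970 nM
Compound 3, `CCc1ccc(NC(=S)N/N=C\c2ccnc3ccccc23)cc1` — compound 3 gives 820 nM

All three compounds share one core and differ only in the group attached to the amide-type nitrogen. The steps between them are small: a 1.0-fold lower number from compound 1 to compound 2 (0.01 log units; within the scatter), a 1.2-fold lower number from compound 1 to compound 3 (0.08 log units; within the scatter) and a 1.2-fold lower number from compound 2 to compound 3 (0.07 log units; within the scatter). Compound 3 has the smallest number of the three, but each of its steps to the others lies within the scatter, so on these numbers it cannot be told apart from compound 1 or compound 2.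

Compound 4 is `S=C(N/N=C\c1ccnc2ccccc12)Nc1ccccc1`. It differs from compound 3 by hydrogen in place of ethyl on an aromatic carbon. Within the data shown here, two measured steps bear on this change, since both also alter what sits at this part of the molecule: a 1.2-fold lower number from compound 1 to compound 3 (0.08 log units; within the scatter) and a 1.2-fold lower number from compound 2 to compound 3 (0.07 log units; within the scatter). Both stayed within the scatter, even where a whole ring was swapped for another. Removing the ethyl group is a smaller change than either of those, so no step beyond the scatter is expected in this assay.

Compound 4 is therefore estimated at 900 nM, with a range from 450 nM to 1800 nM. This estimate means a step of a 1.1-fold higher number from compound 3 to compound 4 (0.04 log units; within the scatter), expected to stay within the scatter.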

Compound 4, half-maximal inhibitory concentration: 1070 nM
Estimate against measurement, compound 4: 1.2-fold (0.08 log units) below, within the range that was stated.
By their numbers in this assay, from the lowest: compounds 3, 2, 1 and 4 (each within the scatter of the next).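

Compound 4 puts a bare hydrogen on the aromatic carbon para to a large group, so this position now has a reference with no substituent at all. In this assay, taking away the ethyl group gives a 1.3-fold higher number from compound 3 to compound 4 (0.12 log units; within the scatter), and taking away the methoxy group gives a 1.1-fold higher number from compound 1 to compound 4 (0.03 log units; within the scatter). Plain phenyl in place of pyridin-3-yl gives a 1.1-fold higher number from compound 2 to compound 4 (0.04 log units; within the scatter), so among these four compounds neither a group at this position nor the swap between these two rings shifts the cytotoxicity number beyond the usual spread of repeat measurements.

Nothing available here offers a reason why the four numbers sit so close together. From the compounds shown here alone, what stays open is whether a different kind of group at this position, such as an amine, a carboxylic acid or a chain longer than ethyl, would produce a step beyond the scatter, and whether a change to the shared core itself would do so where changes to this ring have not.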